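Lengthening the linker between the two aryl ethers

This account rests on a few compounds, and the source may have more. Where it says the series, first, only, none or still open, it means among the compounds named here.

Measured compounds: compound 1 `c1ccc(OCCCCOc2cccc(-c3cc4ccc(C5=NCCN5)cc4o3)c2)cc1` gives 5800 nM; compound 2 `CC(C)NC(=N)c1ccc2oc(-c3ccc(OCCCOc4ccccc4)cc3)cc2c1` gives 45600 nM; compound 3 `c1ccc(OCCCOc2ccc(-c3cc4cc(C5=NCCN5)ccc4o3)cc2)cc1` gives 10300 nM, all in an ADME assay on L6 cells (Rattus norvegicus) for cytotoxicity, read by resazurin assay, with a stated time of 70 h; a lower number here means a stronger inhibitor, a higher number a weaker inhibitor.

Compound 3 stands second highest of the three numbers. Its nearest neighbour is compound 1, a step that lies within the scatter, and its furthest is compound 2, which stands beyond the scatter. Among the compounds with values here, the only single-point step among the measured compounds is a 4.4-fold lower number from compound 2 to compound 3 (0.65 log units; beyond the scatter), which concerns the group on the aromatic carbon of the core and not the linker.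

Compound 4 `c1ccc(OCCCCCOc2ccc(-c3cc4cc(C5=NCCN5)ccc4o3)cc2)cc1` differs from compound 3 in the linker alone: 2-phenoxyethyl in place of phenoxy on a saturated chain carbon, three bonds along the chain from an oxygen on an aromatic ring. Within the data shown here, no measured step bears on this change directly. Compounds 1 and 3 differ in two places, the linker and the position of the ether on the ring, and their two values lie within the scatter of one another; that is the closest the data come to a lengthened linker.

Since nothing shown points in either direction, the step of a 1.1-fold lower number from compound 3 to compound 4 (0.06 log units; within the scatter) is expected to stay within the scatter. Compound 4 is therefore estimated at 9000 nM, within 4000 nM to 22000 nM.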

Compound 4, half-maximal inhibitory concentration: 900 nM
Estimate against measurement, compound 4: 10-fold (1.00 log units) above, and the stated range ends above it.
By their numbers in this assay, from the lowest: compound 4; then compounds 1 and 3 (each within the scatter of the next); then compound 2.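

In this assay, the linker proves to be a sensitive position: an 11-fold lower number from compound 3 to compound 4 (1.06 log units; beyond the scatter), a large step that follows from 2-phenoxyethyl replacing phenoxy on a saturated chain carbon, three bonds along the chain from an oxygen on an aromatic ring. The entering group keeps the same aromatic ring and the same hydrogen-bond donor and acceptor counts as the group that leaves, and it differs in size, with all of the added atoms carbon, so the earlier step on the group attached to the core, the only one read before, now has a counterpart on the linker. Nothing available here explains why this lengthening has so large an effect.

A single step cannot show whether a still longer chain would continue to lower the number or reverse the change, or whether an amine placed within the chain would preserve it. As far as these compounds go, it also remains open whether the same lengthening would have a similar effect alongside the isopropyl amidine of compound 2 or the different ether placement of compound 1.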